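The compounds below may be only part of what the source reports. "The series", "measured", "known", "first", "only" and "open" are said of these compounds alone.

Measured in an ADME assay on cells (Hepatocyte, Mus musculus) for metabolic stability, with a stated time of 30 min; on this read-out higher numbers stand for a more stable compound and lower numbers for a less stable compound:
- compound 1 `O=C(NC1CCC(CN2CCN(c3cc(=O)c4cc(C(F)(F)F)cc([N+](=O)[O-])c4s3)CC2)CC1)c1ccccc1`: 90.6%
- compound 2 `CC(=O)NC1CCC(CN2CCN(c3cc(=O)c4cc(C(F)(F)F)cc([N+](=O)[O-])c4s3)CC2)CC1`: 94.9%

Compound 2 gives 94.9% and stands level with compound 1 within the scatter. The next structure, compound 3 `O=C(OC1CCC(CN2CCN(c3cc(=O)c4cc(C(F)(F)F)cc([N+](=O)[O-])c4s3)CC2)CC1)c1ccc(F)cc1`, carries ((4-fluorophenyl)carbonyl)oxy in place of acetamido on a saturated ring carbon.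

For the measured compounds named here, only one measured step bears on this change. That step, a number 4.3 percentage points higher from compound 1 to compound 2 (within the scatter), put methyl in place of phenyl on a carbonyl carbon and stayed within the scatter. It suggests that the aromatic ring alone need not shift this assay by much. However, neither measured compound carries the ((4-fluorophenyl)carbonyl)oxy group, and no measured step replaces acetamido, so the size of the step remains poorly defined. With compound 2 at 94.9%, there is more room for the number to fall than to rise, so a moderate fall beyond the scatter is expected, though a result within the scatter remains possible.

The expected change is a number 22.9 percentage points lower from compound 2 to compound 3 (beyond the scatter).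

For compound 3 the estimated value is 72%, with an expected range from 38% to 96%.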

Compound 3, percent of the compound remaining: 1.5%
Estimate against measurement, compound 3: 70.5 percentage points above, and the stated range ends above it.
By their numbers in this assay, from the lowest: compound 3; then compounds 1 and 2 (each within the scatter of the next).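

In this assay, the group on this saturated ring carbon turned out to be able to move the read-out almost across its whole span: there is a number 93.4 percentage points lower from compound 2 to compound 3 (beyond the scatter) when ((4-fluorophenyl)carbonyl)oxy replaces acetamido, and the two amides seen earlier gave no sign of a fall of this kind. An aromatic ring in this group does not by itself go with the loss, since benzamido also carries one, and still there is a number 89.1 percentage points lower from compound 1 to compound 3 (beyond the scatter) when ((4-fluorophenyl)carbonyl)oxy takes its place. No measurement shown here offers an explanation for this fall.

The step from benzamido changes the link to the ring carbon and adds fluorine at once, so the compounds shown leave open which of the two goes with the loss. A 4-fluorobenzamido group or an unsubstituted benzoyloxy group on the same carbon would separate them, and an acetyloxy group would show whether the oxygen link goes with a low number without any aromatic ring.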